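Oleyl Ureas and an Amide as Acyltransferase Inhibitors

A few compounds are considered here, and "the series" means these few. Any claim that something is new, unique, unknown or untested is made for them only; others in the source may bear on it.

Compound 1 `CCCCCCCC/C=C\CCCCCCCCNC(=O)c1c(C)cccc1C` gives 9800 nM; compound 2 `CCCCCCCC/C=C\CCCCCCCCNC(=O)Nc1ccc(OC)cc1OC` gives 5400 nM.

In an assay on microsomes from intestinal mucosa for inhibition of acyl-CoA:cholesterol acyltransferase (Oryctolagus cuniculus) (a higher number here means a weaker inhibitor, a lower number a stronger inhibitor), compound 2 holds the lower of the two numbers, yet its gap to compound 1 lies within the scatter, so no order between the two can be read. Compound 3 `CCCCCCCC/C=C\CCCCCCCCNC(=O)Nc1ccccc1CC` differs from compound 2 by one change: 2-ethylphenyl in place of 2,4-dimethoxyphenyl on an amide-type nitrogen. Among the measured compounds shown here, no measured pair shows a step of this kind, so the expectation rests on the change alone. A moderate move toward a lower number is expected, a 1.8-fold lower number from compound 2 to compound 3 (0.26 log units; within the scatter). Compound 3 is expected near 3000 nM, with a range from 800 nM to 12000 nM.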

Compound 3, half-maximal inhibitory concentration: 980 nM
Compound 3: middle estimate off by 3.1-fold (0.49 log units), on the high side, and the stated range covers the measured number.
By their numbers in this assay, from the lowest: compound 3; then compounds 2 and 1 (each within the scatter of the next).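

In this assay, the group on the amide-type nitrogen now moves the number beyond the scatter, which compound 1 and compound 2 alone could not show: 2-ethylphenyl in place of 2,4-dimethoxyphenyl gives a 5.5-fold lower number from compound 2 to compound 3 (0.74 log units; beyond the scatter). Putting (2-ethylphenyl)amino in place of 2,6-dimethylphenyl on the carbonyl carbon gives a 10-fold lower number from compound 1 to compound 3 (1.00 log units; beyond the scatter). Nothing available here accounts for either step.

Since the ethyl group enters as the two methoxy groups leave, the compounds shown cannot tell which part of the change carries the step. Going by these compounds, whether an unsubstituted phenyl or a 2-methoxyphenyl on that nitrogen would hold the lower number remains open.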